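From 2-fluoro-5-nitrophenyl to 2-fluoro-4-nitrophenyl at a solubility limit

The source may report more compounds than this note shows. Statements on the series, on what has been measured and on what is new or still open speak of the compounds shown alone.

In a physicochemical assay for solubility (a higher number here means a more soluble compound, a lower number a less soluble compound), compound 1 `O=C(O)c1ccc(C(=O)/C(=C\c2ccc(O)c([N+](=O)[O-])c2)SCc2ccc(Br)cc2)cc1` gives < 1000 ug/mL, which is a limit and not a number. Compound 2 `O=C(O)c1ccc(C(=O)/C(=C\c2cc([N+](=O)[O-])ccc2F)SCc2ccc(Br)cc2)cc1` gives < 1000 ug/mL, which is also a limit. Compound 2 therefore stands at the limit of < 1000 ug/mL in this assay, at which 2 of the 2 values shown sit.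

Compound 3 `O=C(O)c1ccc(C(=O)/C(=C\c2ccc([N+](=O)[O-])cc2F)SCc2ccc(Br)cc2)cc1` carries 2-fluoro-4-nitrophenyl in place of 2-fluoro-5-nitrophenyl on a double-bonded chain carbon bound to a double-bonded chain carbon, with the same atoms joined differently: 2-fluoro-4-nitrophenyl in place of 2-fluoro-5-nitrophenyl on a double-bonded chain carbon bound to a double-bonded chain carbon.

Within the data shown here, the only measured step that bears on this change, a step that the two limits leave unreadable from compound 1 to compound 2, concerns the same place, but its size cannot be read. With no measured size to carry over, no direction can be expected, and no step beyond the usual scatter is expected in this assay. The expected step is a step that the limit leaves unreadable from compound 2 to compound 3. Compound 3 is estimated at 600 ug/mL, within a range of 200 ug/mL to 1000 ug/mL, and will probably be reported only as a limit.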

Compound 3, solubility: < 1000 ug/mL
Compound 3: a limit, no number; the forecaster's own chance of this, stated with the estimate: 90%; the middle value does not contradict the limit.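

No step between compound 1, compound 2 and compound 3 can be read, since each gives a limit and not a number in this assay: the limit of < 1000 ug/mL in this assay, at which 3 of the 3 values shown sit.

Going by these compounds, the actual value of each compound stays open, and so does whether 4-hydroxy-3-nitrophenyl, 2-fluoro-5-nitrophenyl and 2-fluoro-4-nitrophenyl differ at all in this read-out.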